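The compounds below may be only part of what the source reports. "The series", "measured", "known", "first", "only" and "open" are said of these compounds alone.

Compound 1, `O=C(CCSc1nc2cc(F)ccc2o1)N1CCCC1`: 5.2 mL/min/g
Compound 2, `O=C1CCCN1CCCSc1nc2cc(Cl)ccc2o1`: 4.8 mL/min/g
Compound 3, `O=C(CCSc1nc2cc(Cl)ccc2o1)NC1CCCC1`: 11.3 mL/min/g

All three compounds share the same core and were examined in an ADME assay on microsomes from liver (Homo sapiens) for metabolic stability, read by LC-MS, using NADPH, with a stated time of 45 min, tested at 0.5 uM; a lower number here means slower removal, a higher number faster removal of the compound. Among the three numbers compound 3 gives the highest, with 11.3 mL/min/g; compound 1 lies nearest below it and compound 2 furthest, and both of those gaps lie beyond the usual scatter of the measurement, so compound 3 is cleared faster than either.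

Compound 4, `CCN(CC)C(=O)CCSc1nc2cc(Cl)ccc2o1`, has not yet been measured in this assay. It differs from compound 3 in one place: diethylamino in place of cyclopentylamino on a carbonyl carbon. The hydrogen-bond donor that leaves with the cyclopentylamino group is thus gone in compound 4, which in that respect brings it closer to compound 1 and compound 2, the two compounds with lower numbers.

Among the measured compounds shown here, no step between measured compounds is available to set the size of this change directly. Judged only from the values in hand, the step of a 1.6-fold lower number from compound 3 to compound 4 (0.21 log units; within the scatter) is expected to be modest and downward, possibly no larger than the scatter. Compound 4 is therefore estimated to give 7 mL/min/g, with a likely range from 3.5 mL/min/g to 14 mL/min/g.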

Compound 4, intrinsic clearance in a liver preparation (reported as CLH), per the amount of preparation that the assay uses: 5.9 mL/min/g
For compound 4 the middle estimate is 1.2-fold (0.07 log units) above the measured one; low and high end bracket the measured number.
By their numbers in this assay, from the lowest: compounds 2, 1, 4 and 3 (each within the scatter of the next, the first and the last beyond it).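

In this assay, the change to diethylamino in place of cyclopentylamino on a carbonyl carbon gives a 1.9-fold lower number from compound 3 to compound 4 (0.28 log units; within the scatter) and is the first step shown between two compounds that differ in one place only. That single swap removes a five-membered ring of carbon and a hydrogen-bond donor together, yet the two compounds cannot be told apart in this measurement, so for this pair, losing both features at once leaves no change that stands clear of the usual scatter. Nothing measured here gives a reason for this result.

The ring and the donor leave in the same step. The compounds shown cannot reveal what each does alone, or whether the two have separate effects that happen to offset each other. Ethylamino on the same carbonyl carbon, or morpholin-4-yl there, would each test this place in a different way, and how either would behave in this assay remains open.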